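The source may hold more compounds than are shown below. What is called first, only, known or untested is meant among the compounds shown, and "the series" means these compounds.

Measured so far in an assay on BaF3 cells for inhibition of proto-oncogene tyrosine-protein kinase receptor Ret variant V804M (Homo sapiens), read by MTT assay, with a stated time of 48 h; a higher number here means a weaker inhibitor of growth, a lower number a stronger inhibitor of growth. Compound 1 `CC(C)n1nc(-c2cc(C3CCCCC3)on2)c2c(N)ncnc21` gives 4730 nM. Compound 2 `Nc1ncnc2c1c(-c1cc(C3CC3)on1)nn2C1CCCCC1` gives 2000 nM. Compound 3 `CCCCCCCn1nc(-c2cc(C3CC3)on2)c2c(N)ncnc21` gives > 10000 nM, which is a limit of this assay rather than a number.

Compound 1 stands highest of the two numbers; the gap to compound 2 is beyond the scatter. Within the data shown here, the one measured step, an at least 5.0-fold higher number from compound 2 to compound 3 (0.69 log units; beyond the scatter), concerns the group on the aromatic nitrogen and is marked by the limit of > 10000 nM in this assay, at which 1 of the 3 values shown sits. It does not touch the group on the five-membered ring.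

Compound 4 `CC(C)n1nc(-c2cc(-c3ccccc3)on2)c2c(N)ncnc21` differs from compound 1 by phenyl in place of cyclohexyl on an aromatic carbon. Among the measured compounds shown here, no measured step bears on this change, so no step beyond the scatter is expected, a 1.1-fold lower number from compound 1 to compound 4 (0.02 log units; within the scatter). Compound 4 is estimated at 4500 nM, with a range from 1500 nM to 12000 nM.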

Compound 4, concentration for 50% growth inhibition: 4970 nM
For compound 4 the middle estimate is 1.1-fold (0.04 log units) below the measured one; low and high end bracket the measured number.
By their numbers in this assay, from the lowest: compound 2; then compounds 1 and 4 (each within the scatter of the next). At a limit, above all of these: compound 3.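

In this assay, phenyl in place of cyclohexyl on an aromatic carbon next to the ring oxygen gives a 1.1-fold higher number from compound 1 to compound 4 (0.02 log units; within the scatter), so on the core of compound 1 these two six-membered rings cannot be told apart at this position. Both carry the same heavy-atom count, and the aromatic ring alone separates them. Nothing measured here offers a reason for this result.

Going by these compounds, whether a small group such as methyl, or a phenyl ring bearing an amine or a carboxylic acid, would shift the number at this position stays open. Also open, on these data alone, is how far any group here can move the number at all.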